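Moving the pyridine group: compound 3 to compound 4

The compounds below may be only part of what the source reports. "The series", "measured", "known", "first", "only" and "open" are said of these compounds alone.

Measured so far in a functional assay on RPTEC cells (Homo sapiens) for antiproliferative activity; on this read-out higher numbers stand for weaker inhibition of growth and lower numbers for stronger inhibition of growth:
- compound 1 `c1ccc(-c2cc(-c3ccsc3)cc(-c3cccnc3)n2)nc1` gives 0.31 ug/mL
- compound 2 `c1ccc(-c2cc(-c3cccs3)cc(-c3ccccn3)n2)nc1` gives 0.0016 ug/mL
- compound 3 `c1ccc(-c2cc(-c3cccs3)cc(-c3ccncc3)n2)nc1` gives 0.65 ug/mL

Compound 3 has the highest number of the three. Compound 1 lies nearest to it, and compound 2 lies furthest away.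

Compound 4 `c1ccc(-c2cc(-c3cccs3)cc(-c3cccnc3)n2)nc1` has pyridin-3-yl in place of pyridin-4-yl on an aromatic carbon and is otherwise the same as compound 3. Among the measured compounds shown here, the only measured step at this place is a 410-fold higher number from compound 2 to compound 3 (2.61 log units; beyond the scatter), a large one, but it starts from pyridin-2-yl and does not compare the two groups exchanged here. Compound 1 carries pyridin-3-yl at the same place, with its thiophene joined differently, and gives 0.31 ug/mL as the closest guide. A small move towards a lower number is therefore expected in this assay, with nothing like the large step above. The expected change is a 1.6-fold lower number from compound 3 to compound 4 (0.21 log units; within the scatter) as an estimate. Compound 4 is estimated at 0.4 ug/mL, with an expected range of 0.12 ug/mL to 1.3 ug/mL for this value.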

Compound 4, concentration for 50% growth inhibition: 0.056 ug/mL
Beside the measured number, compound 4's estimate is 7.1-fold (0.85 log units) above it, outside the stated range (below it).
By their numbers in this assay, from the lowest: compound 2; then compound 4; then compound 1; then compound 3.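

In this assay, pyridin-3-yl in place of pyridin-4-yl gives a 12-fold lower number from compound 3 to compound 4 (1.06 log units; beyond the scatter) and pyridin-3-yl in place of pyridin-2-yl gives a 35-fold higher number from compound 2 to compound 4 (1.54 log units; beyond the scatter) at the same place, so the exchange is large in both directions even though the groups have the same atoms. With thiophen-2-yl held constant, compounds 2, 4 and 3 complete the pyridine series and run from lowest to highest number as pyridin-2-yl, pyridin-3-yl and pyridin-4-yl, with every step beyond the scatter. With pyridin-3-yl held constant, the thiophene attachment also matters, as thiophen-2-yl in place of thiophen-3-yl gives a 5.5-fold lower number from compound 1 to compound 4 (0.74 log units; beyond the scatter) and remains a modest step.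

As far as these compounds go, whether a piperidine ring at the pyridine place or an amino group on the pyridin-2-yl ring would keep the low number of compound 2 remains open. The data do not show what lies behind the size of these steps. No evidence bearing on this result is available.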